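The source may hold more compounds than are shown below. What is called first, only, known or untested is meant among the compounds shown, and "the series" means these compounds.

Working notes on the series. Compound 1 `C=C1C[C@]23C[C@@]1(O)CC[C@@H]2c1cccc(C)c1[C@@H]3Cn1cc(-c2ccc(F)cc2)nn1` and compound 2 `C=C1C[C@]23C[C@@]1(O)CC[C@@H]2c1cccc(C)c1[C@@H]3Cn1cc(-c2ccc(C(F)(F)F)cc2)nn1` share one core, which carries a 4-fluorophenyl group in compound 1 and a 4-(trifluoromethyl)phenyl group in compound 2. In a functional assay on HL-60 cells (Homo sapiens) for cytotoxicity, read by MTT assay, with a stated time of 4 days (a higher number here means a weaker inhibitor, a lower number a stronger inhibitor), compound 1 gives only a limit, > 20000 nM. In this assay compound 2 likewise gives only a limit, > 20000 nM. The change from compound 2 to compound 1 is fluoro in place of trifluoromethyl on an aromatic carbon. Its step, a step that the two limits leave unreadable from compound 2 to compound 1, has no readable size because of the limit of > 20000 nM in this assay, at which 3 of the 3 values shown sit.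

Compound 3 `Cc1ccc(S(=O)(=O)Oc2ccc3c(c2C)[C@H](Cn2cc(-c4ccc(C(F)(F)F)cc4)nn2)[C@@]24CC(=O)[C@@](C)(CC[C@@H]32)C4)cc1` is built on a second core; the difference between the two cores is not broken down here. In this assay compound 3 also gives only a limit, > 20000 nM.

Compound 4 `Cc1ccc(S(=O)(=O)Oc2ccc3c(c2C)[C@H](Cn2cc(-c4ccc(F)cc4)nn2)[C@@]24CC(=O)[C@@](C)(CC[C@@H]32)C4)cc1` has the core of compound 3 and differs from it by fluoro in place of trifluoromethyl on an aromatic carbon. The place of the change reads the same word for word in both pairs, so this is the same kind of change carried onto the second core. Among the compounds with values here, nothing measured here separates the two cores, and the one measured instance of the change gives no size.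

Compound 4 is therefore expected to show a step that the limit leaves unreadable from compound 3 to compound 4, a step of no readable size, most likely ending again at the limit. This expectation rests on compound 3 giving > 20000 nM. It rests further on a step that the two limits leave unreadable from compound 2 to compound 1. Compound 4 is estimated at 30000 nM, with a range from 15000 nM to 80000 nM.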

Compound 4, half-maximal inhibitory concentration: > 20000 nM
Compound 4: only a limit was reported (the forecaster's own chance of this, stated with the estimate: 85%); the middle value does not contradict the limit.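

In this assay, no size can be read for the step from 4-(trifluoromethyl)phenyl to 4-fluorophenyl between compound 3 and compound 4, because both compounds give only a limit: the limit of > 20000 nM in this assay, at which 4 of the 4 values shown sit.

The compounds shown leave open whether the change has any effect on either core, and whether the two cores differ at all in this assay.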